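This account rests on a few compounds, and the source may have more. Where it says the series, first, only, none or still open, it means among the compounds named here.

Compound 2 `Nc1nc(Cl)c2ncn(Cc3ccc(CCl)cc3)c2n1` gives the highest number of the three measured compounds in a functional assay on NCI-H322M cells (Homo sapiens) for cytotoxicity, read by sulforhodamine B assay, with a stated time of 48 h (a lower number here means a stronger inhibitor of growth, a higher number a weaker inhibitor of growth), at 21400 nM. Compound 1 `ClCc1ccc(Cn2cnc3c(Cl)ncnc32)cc1` gives 1820 nM and compound 3 `ClCc1cccc(Cn2cnc3c(Cl)nc(Cl)nc32)c1` gives 2290 nM, both well separated from compound 2. The step to compound 4 `ClCc1ccc(Cn2cnc3c(Cl)nc(Cl)nc32)cc1` is chloro in place of amino on an aromatic carbon. Among the compounds with values here, the one measured step that bears on it runs the other way: a 12-fold higher number from compound 1 to compound 2 (1.07 log units; beyond the scatter), and compound 3, which carries the same two chloro groups on the core as compound 4, sits close to compound 1. Removing the amino group is therefore expected to lower the number by a large margin, a 9.7-fold lower number from compound 2 to compound 4 (0.99 log units; beyond the scatter). Compound 4 is expected to give 2200 nM, with a range from 1000 nM to 5000 nM.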

Compound 4, concentration for 50% growth inhibition: 12600 nM
For compound 4 the middle estimate is 5.7-fold (0.76 log units) below the measured one; the measured number lies above the stated range.
By their numbers in this assay, from the lowest: compounds 1 and 3 (each within the scatter of the next); then compounds 4 and 2 (each within the scatter of the next).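

In this assay, amino and chloro on this aromatic carbon between two ring nitrogen atoms cannot be told apart, with a 1.7-fold lower number from compound 2 to compound 4 (0.23 log units; within the scatter). Against hydrogen at the same place, chloro also gives a 6.9-fold higher number from compound 1 to compound 4 (0.84 log units; beyond the scatter), so the higher number seen with amino is not particular to amino: both groups go with a higher number than hydrogen. Nothing available accounts for this. On these data alone, whether any group here does the same, or only these two, stays open. A methyl, a methoxy or a fluoro at this position would test that.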